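Swapping the morpholin-4-yl group of compound 2

The source may report more compounds than this note shows. Statements on the series, on what has been measured and on what is new or still open speak of the compounds shown alone.

In a functional assay on A20 cells (Mus musculus) for inhibition, with stated times of 1 h, 16 h and 24 h (on this read-out lower numbers stand for stronger inhibition and higher numbers for weaker inhibition), compound 2 `N#CC1(NC(=O)[C@@H]2C[C@@H](S(=O)(=O)c3ccccc3)C[C@H]2C(=O)N2CCOCC2)CC1` gives 12 nM and so holds the middle of three measured numbers. Compound 1 `N#CCNC(=O)[C@@H]1C[C@@H](S(=O)(=O)c2ccccc2Cl)C[C@H]1C(=O)N1CCOCC1` shows the lowest number with 3 nM and compound 3 `N#CC1(NC(=O)[C@@H]2C[C@@H](S(=O)(=O)c3ccccc3)C[C@H]2C(=O)N2CCOCC2)CCC1` the highest with 236 nM on the same scale. Compound 4 `N#CC1(NC(=O)[C@@H]2C[C@@H](S(=O)(=O)c3ccccc3)C[C@H]2C(=O)N2CC3(COC3)C2)CC1` is still unmeasured. The change from compound 2 is a group of 7 heavy atoms (5 carbon, 1 nitrogen, 1 oxygen; 2 four-membered non-aromatic rings with 1 hetero atom each) in place of a group of 6 heavy atoms (4 carbon, 1 nitrogen, 1 oxygen; one six-membered non-aromatic ring with 2 hetero atoms), on a carbonyl carbon and nothing else differs. Within the data shown here, all three measured compounds carry the morpholin-4-yl group, so no measured step tests this swap. Among the measured compounds shown here, the one measured step of a 20-fold higher number from compound 2 to compound 3 (1.29 log units; beyond the scatter) is large, but it concerns another part of the molecule. It shows that this assay can respond strongly to a single change, yet it gives no direction for compound 4. With no direct evidence, no step beyond the scatter is expected, and the range must stay wide on both sides. The expected step is a 1.3-fold higher number from compound 2 to compound 4 (0.10 log units; within the scatter) and this is only a cautious guess. The estimate for compound 4 is 15 nM with 4 nM to 60 nM as its range.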

Compound 4, half-maximal inhibitory concentration: 248 nM
Compound 4: middle estimate off by 17-fold (1.22 log units), on the low side, and the stated range ends below it.
By their numbers in this assay, from the lowest: compound 1; then compound 2; then compounds 3 and 4 (each within the scatter of the next).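

In this assay the group on the carbonyl carbon proves to be far from a free place for change: putting the group with two four-membered rings in place of morpholin-4-yl gives a 21-fold higher number from compound 2 to compound 4 (1.32 log units; beyond the scatter) on the same core. The two groups match in hydrogen-bond donors, hydrogen-bond acceptors and net charge, so those counts alone do not tell how this assay will respond here. Besides the 1-cyanocyclopropyl group, where the swap gives a 20-fold higher number from compound 2 to compound 3 (1.29 log units; beyond the scatter) in the same series, this is a second place where one change moves the number strongly, and nothing measured here accounts for it.

Still open, on these data alone, is whether a simpler six-membered ring such as piperidin-1-yl, or an open-chain dimethylamino group, would stay close to compound 2 . The compounds shown also cannot separate the part played by the ring size from that of the extra atoms in the new group.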